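Chloro in place of methyl: compound 2 to compound 3

A few compounds are considered here, and "the series" means these few. Any claim that something is new, unique, unknown or untested is made for them only; others in the source may bear on it.

Two compounds have numbers in an assay on isolated protein for inhibition of kynurenine 3-monooxygenase (Rattus norvegicus); on this read-out lower numbers stand for stronger inhibition and higher numbers for weaker inhibition. Compound 1 `Cc1ccc(-c2csc(NS(=O)(=O)c3ccc(C)cc3)n2)cc1` gives 76 nM. Compound 2 `Cc1ccc(S(=O)(=O)Nc2nc(-c3cccc([N+](=O)[O-])c3)cs2)cc1` gives 48 nM, the lower of the two numbers, though compound 1 sits within the usual scatter of it, so no order is drawn between them. Compound 3 `O=[N+]([O-])c1cccc(-c2csc(NS(=O)(=O)c3ccc(Cl)cc3)n2)c1` has not been measured. It differs from compound 2 by chloro in place of methyl on an aromatic carbon; the same difference, cut one bond further out, reads 4-methylphenyl to 4-chlorophenyl. Among the measured compounds shown here, no measured pair carries this exchange, so there is no step to lean on, and this place is not otherwise varied among the measured compounds. The step is expected to be a 1.1-fold lower number from compound 2 to compound 3 (0.03 log units; within the scatter), none beyond the scatter in either direction. Compound 3 is therefore estimated at 45 nM, with a range from 18 nM to 120 nM.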

Compound 3, half-maximal inhibitory concentration: 84 nM
Beside the measured number, compound 3's estimate is 1.9-fold (0.27 log units) below it, within the range that was stated.
By their numbers in this assay, from the lowest: compounds 2, 1 and 3 (each within the scatter of the next).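

In this assay, among the compounds shown here, this is the first reading at the place para to a large group, which the earlier compounds did not vary, and chloro in place of methyl gives a 1.8-fold higher number from compound 2 to compound 3 (0.24 log units; within the scatter) on that aromatic carbon. The exchange of 4-methylphenyl for 4-chlorophenyl therefore separates no order between the two compounds, and this one pair shows no sensitivity at this place to the change from methyl to chloro. No measurement available here accounts for the step.

With methyl and chloro the only groups shown at this place, its response to an amine, a carboxylic acid or a longer alkyl chain remains open. Also open, on these data alone, is whether chloro in place of methyl reads the same on the core of compound 1, which carries a different group at its other end.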